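Second chloro on the benzoyl ring of compound 3

A few compounds are considered here, and "the series" means these few. Any claim that something is new, unique, unknown or untested is made for them only; others in the source may bear on it.

Measured so far:
compound 1, `COC(=O)C(=N)/C=C(\O)c1cccc(Cl)c1Cl`: 33%
compound 2, `N/C(=C\C(=O)c1ccccc1)C(=O)O`: 17%
compound 3, `N/C(=C\C(=O)c1ccccc1Cl)C(=O)O`: 19%

In an assay for inhibition of kynurenine 3-monooxygenase (Rattus norvegicus), tested at 10 uM (on this read-out higher numbers stand for more inhibition at the one concentration tested (going by the name of the read-out) and lower numbers for less inhibition), compound 3 gives 19%, the second highest of the three numbers. Its nearest neighbour is compound 2 at 17%, a difference within the scatter, while compound 1 at 33% stands beyond the scatter above it.

Compound 4, `N/C(=C\C(=O)c1cccc(Cl)c1Cl)C(=O)O`, differs from compound 3 by chloro in place of hydrogen on an aromatic carbon. Among the measured compounds shown here, the one measured step that bears on such a change is the one from compound 2 to compound 3, a number 2 percentage points higher from compound 2 to compound 3 (within the scatter), which stayed within the scatter. Compound 1 carries the same two chloro groups as compound 4 but on a different core, so its higher number can only be noted, not used as a step. Expected, then, is a number 5 percentage points higher from compound 3 to compound 4 (within the scatter) in this assay, a small move upward that may still lie within the scatter. The estimate for compound 4 is 24%, with a range from 10% to 40%.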

Compound 4, a percentage reported as inhibition, at one concentration (the size of the read-out at that concentration, not a potency): 32%
The estimate for compound 4 lay 8 percentage points below the measured number, within the range that was stated.
By their numbers in this assay, from the lowest: compounds 2 and 3 (each within the scatter of the next); then compounds 4 and 1 (each within the scatter of the next).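

In this assay the exchange of hydrogen for chloro on an aromatic carbon gives a number 13 percentage points higher from compound 3 to compound 4 (beyond the scatter) when the new chloro group stands ortho to a chloro group and meta to a group of 8 heavy atoms. Among the compounds shown here, the earlier exchange gave a number 2 percentage points higher from compound 2 to compound 3 (within the scatter), so this is the first such exchange here to move the number beyond the scatter. Nothing at hand accounts for this result.

The compounds shown do not tell whether this chloro group would give a similar step without the first chloro group present. They also leave open whether a fluoro, a bromo or a methoxy group on the same aromatic carbon would give a number like that of compound 4.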